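This account rests on a few compounds, and the source may have more. Where it says the series, first, only, none or still open, it means among the compounds named here.

Compound 1 `COc1ccc(-n2c(SCc3ccc(F)cc3)nnc2-c2cc(OC)c(OC)c(OC)c2)cc1`: 38700 nM in a functional assay on HCT-116 cells (Homo sapiens) for inhibition, read by MTT assay, with a stated time of 48 h; on this read-out lower numbers stand for stronger inhibition and higher numbers for weaker inhibition
Compound 2 `COc1ccc(-n2c(SCC(=O)c3ccccc3)nnc2-c2cc(OC)c(OC)c(OC)c2)cc1`: a limit of this assay, > 60000 nM
Compound 3 `COc1cc(-c2nnc(SCc3ccc(F)cc3)n2-c2ccc(N(C)C)cc2)cc(OC)c1OC`: a limit of this assay, > 60000 nM

The change from compound 1 to compound 2 is benzoyl in place of 4-fluorophenyl on a saturated chain carbon bound to a sulfur, and it made an at least 1.5-fold higher number from compound 1 to compound 2 (0.19 log units; that floor lies within the scatter). The reading rests on (the limit of > 60000 nM in this assay, at which 2 of the 3 values shown sit). The cores of compound 1 and compound 3 differ by dimethylamino in place of methoxy on an aromatic carbon, which made an at least 1.5-fold higher number from compound 1 to compound 3 (0.19 log units; that floor lies within the scatter). Compound 4 `COc1cc(-c2nnc(SCC(=O)c3ccccc3)n2-c2ccc(N(C)C)cc2)cc(OC)c1OC` has not been measured; it carries benzoyl in place of 4-fluorophenyl on a saturated chain carbon bound to a sulfur, the same change at the same place as between compound 1 and compound 2. Compound 3 already sits at the limit > 60000 nM, and that is the footing here. The step expected alongside the earlier one is a step that the limit leaves unreadable from compound 3 to compound 4. Compound 4 is therefore estimated at 90000 nM, between 45000 nM and 250000 nM, most likely again reported only as a limit.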

Compound 4, half-maximal inhibitory concentration: 42500 nM
Beside the measured number, compound 4's estimate is 2.1-fold (0.33 log units) above it; measured number below the stated range.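

In this assay, benzoyl in place of 4-fluorophenyl on a saturated chain carbon bound to a sulfur gave an at least 1.4-fold lower number from compound 3 to compound 4 (0.14 log units; that floor lies within the scatter), and dimethylamino in place of methoxy on an aromatic carbon gave an at least 1.4-fold lower number from compound 2 to compound 4 (0.14 log units; that floor lies within the scatter). These results do not show whether the benzoyl change carries the same way from one core to the other: the same change on two cores in this assay, an at least 1.5-fold higher number (0.19 log units; that floor lies within the scatter) from compound 1 to compound 2 and an at least 1.4-fold lower number (0.14 log units; that floor lies within the scatter) from compound 3 to compound 4; the limit leaves it open whether they differ. The dimethylamino change remains just as unsettled: the same change on two cores in this assay, an at least 1.5-fold higher number (0.19 log units; that floor lies within the scatter) from compound 1 to compound 3 and an at least 1.4-fold lower number (0.14 log units; that floor lies within the scatter) from compound 2 to compound 4; the limit leaves it open whether they differ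

The compounds shown leave open what a longer chain or a carboxylic acid would do on that saturated chain carbon bound to a sulfur. Going by these compounds, compound 2 and compound 3 are each known only as a limit, and how far their true values lie from compound 4 stays open.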